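The source may report more compounds than this note shows. Statements on the series, on what has been measured and on what is new or still open speak of the compounds shown alone.

Compound 1 `Cc1c(C(=O)N/N=C\c2ccccc2F)oc2cccc(O)c12` reaches only a limit in a functional assay on PC-3 cells (Homo sapiens) for inhibition (on this read-out higher numbers stand for weaker inhibition and lower numbers for stronger inhibition), where compound 1 gives >= 40000 nM. Compound 2 `Cc1c(C(=O)N/N=C\c2cccc(F)c2O)oc2cccc(O)c12` gives 12700 nM in this assay, and the step of an at least 3.1-fold lower number from compound 1 to compound 2 (0.49 log units; beyond the scatter). Compound 3 `Cc1c(C(=O)N/N=C\c2cc(Cl)cc(Cl)c2O)oc2cccc(O)c12` gives 9590 nM in this assay and sits at the low end of the two numbers shown, with compound 2 within the scatter of it. Compound 4 `Cc1c(C(=O)N/N=C\c2cc(Cl)ccc2O)oc2cccc(O)c12` differs from compound 3 by hydrogen in place of chloro on an aromatic carbon. Among the measured compounds shown here, no measured step removes a chloro group; the single measured step, from compound 1 to compound 2, concerns a different exchange and gives no direct guide, so no change beyond the scatter is expected here. The step from compound 3 to compound 4 is estimated as a 1.6-fold higher number from compound 3 to compound 4 (0.19 log units; within the scatter). Compound 4 is expected to give 15000 nM, between 6000 nM and 40000 nM.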

Compound 4, half-maximal inhibitory concentration: 3120 nM
Compound 4: middle estimate off by 4.8-fold (0.68 log units), on the high side; the whole stated range lies above it.
By their numbers in this assay, from the lowest: compound 4; then compounds 3 and 2 (each within the scatter of the next). At a limit, above all of these: compound 1.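

In this assay, among the compounds shown here, the chloro group ortho to a hydroxy group can go without loss: hydrogen in its place gives a 3.1-fold lower number from compound 3 to compound 4 (0.49 log units; beyond the scatter) and yields the first step beyond the scatter among the hydroxyphenyl compounds. The change of ring substitution gives a 4.1-fold lower number from compound 2 to compound 4 (0.61 log units; beyond the scatter) as well, whereas compounds 2 and 3 stood within the scatter of each other. The largest step, an at least 12-fold lower number from compound 1 to compound 4 (1.10 log units; beyond the scatter), rests on a limit and not a number: the limit of >= 40000 nM in this assay, at which 1 of the 4 values shown sits. The compounds shown leave open how a methoxy group or an amine at this position would compare with hydrogen and chloro.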